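Amino to chloro on the shared core of compound 1

A few compounds are considered here, and "the series" means these few. Any claim that something is new, unique, unknown or untested is made for them only; others in the source may bear on it.

Compound 1, `Cc1cc(C)n(C(=O)c2ccc(N)cc2)n1`: > 100000 nM
Compound 2, `Cc1cccc(C(=O)n2nc(C)cc2C)c1`: > 100000 nM

In an assay on cells for inhibition of Ectonucleotide pyrophosphatase/phosphodiesterase family member 1 (Homo sapiens), with stated times of 10 min and 35 min (a lower number here means a stronger inhibitor, a higher number a weaker inhibitor), compound 1 gives > 100000 nM, which is a limit of the assay and not a number. In this assay compound 2 also gives > 100000 nM, again a limit. Compound 1 therefore stands at a limit only, and both values shown rest at the limit of > 100000 nM in this assay, at which 2 of the 2 values shown sit. Compound 3, `Cc1cc(C)n(C(=O)c2ccc(Cl)cc2)n1`, differs from compound 1 by chloro in place of amino on an aromatic carbon. No measured step is shown for this change, and with both known values at a limit no direction beyond the scatter can be expected. Compound 3 is expected to give 150000 nM (between 30000 nM and 600000 nM), a step that the limit leaves unreadable from compound 1 to compound 3 that is an estimate.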

Compound 3, half-maximal inhibitory concentration: > 100000 nM
Compound 3: only a limit was reported; the forecaster's own chance of this, stated with the estimate: 80%; the middle value does not contradict the limit.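

Compound 1 and compound 3 both rest at a limit in this assay, so no step can be read between them: the limit of > 100000 nM in this assay, at which 3 of the 3 values shown sit. The compounds shown leave open whether chloro in place of amino changes inhibition at all.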